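Chloro for Fluoro on a Second Core

A few compounds are considered here, and "the series" means these few. Any claim that something is new, unique, unknown or untested is made for them only; others in the source may bear on it.

Two compounds built on one core were measured in a functional assay on A549 cells (Homo sapiens) for inhibition, read by MTT assay, with a stated time of 48 h; a lower number here means a stronger inhibitor of growth, a higher number a weaker inhibitor of growth. Compound 1 `Cn1cc(C2CC(c3ccc(F)cc3)=NN2C(=O)c2cccnc2)c2cc(Br)ccc21` gives 1380 nM, while compound 2 `Cn1cc(C2CC(c3ccc(Cl)cc3)=NN2C(=O)c2cccnc2)c2cc(Br)ccc21` gives 7650 nM. The change between them, (chloro in place of fluoro on an aromatic carbon), produced a step of a 5.5-fold higher number from compound 1 to compound 2 (0.74 log units; beyond the scatter). Compound 3 `COc1ccc2c(c1)c(C1CC(c3ccc(F)cc3)=NN1C(=O)c1ccc(OC)nc1)cn2C` stands on a different core, and in this assay compound 3 gives 710 nM. The difference between the two cores is not broken down here; the two values of compound 1 and compound 3 lie within the scatter of each other, so no order between them is claimed.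

Compound 4 `COc1ccc2c(c1)c(C1CC(c3ccc(Cl)cc3)=NN1C(=O)c1ccc(OC)nc1)cn2C` has not yet been measured in this assay. It differs from compound 3 by chloro in place of fluoro on an aromatic carbon, and the place of the change reads the same as in the pair already measured. Within the data shown here, the account expects a step of a 3.5-fold higher number from compound 3 to compound 4 (0.55 log units; beyond the scatter), which rests on the single earlier step of a 5.5-fold higher number from compound 1 to compound 2 (0.74 log units; beyond the scatter) and is tempered toward a smaller size, since one example is a thin basis. Compound 4 is expected to give about 2500 nM, plausibly between 900 nM and 7000 nM.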

Compound 4, concentration for 50% growth inhibition: 3390 nM
The estimate for compound 4 lay 1.4-fold (0.13 log units) below the measured number; the range from low to high includes it.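

In this assay, replacing 4-fluorophenyl with 4-chlorophenyl on the second core gave a 4.8-fold higher number from compound 3 to compound 4 (0.68 log units; beyond the scatter), so the change again went with a higher number, meaning a weaker inhibitor of growth. The size of the step also carried over from the first core, as the two steps are indistinguishable: the same change on two cores in this assay, a 5.5-fold higher number (0.74 log units; beyond the scatter) from compound 1 to compound 2 and a 4.8-fold higher number (0.68 log units; beyond the scatter) from compound 3 to compound 4, 1.2-fold (0.06 log units) apart, within the scatter of two such steps This shows that, across these two pairs and in this one assay, the step from fluoro to chloro kept its direction and size on both cores, but it does not show that the same would hold on a third core or in another assay, and it does not explain why the step occurs.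

The compounds shown leave open what a bromo, a methyl, a methoxy or an amine would do in place of the halogen on this phenyl ring. They also leave open which of the several differences between the two cores matters, since the cores differ in more than one place.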